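The source may hold more compounds than are shown below. What is called first, only, known or untested is meant among the compounds shown, and "the series" means these compounds.

Measured compounds in an assay on cells for displacement of a labelled ligand from somatostatin receptor type 2 (Homo sapiens), with a stated time of 90 min; a lower number here means a stronger inhibitor, a higher number a weaker inhibitor:
compound 1 `Clc1ccc(Cn2c(CCc3c[nH]cn3)nnc2Cc2c[nH]c3ccccc23)cc1Cl` gives > 10000 nM, a limit of the assay.
compound 2 `NCCCc1nnc(CCc2c[nH]c3ccccc23)n1Cc1ccccc1` gives > 10000 nM, a limit of the assay.
compound 3 `NCCCc1nnc(CCc2c[nH]c3ccccc23)n1Cc1ccc(Cl)c(Cl)c1` gives > 10000 nM, a limit of the assay.

Compound 3 therefore stands where the other two stand: at the limit rather than at a number, as the limit of > 10000 nM in this assay, at which 3 of the 3 values shown sit, records for all three values shown. For the measured compounds named here, the one measured step, a step that the two limits leave unreadable from compound 2 to compound 3, cannot be read in size because both ends are limits. The change now followed, from compound 3 to compound 4 `Clc1ccc(Cn2c(CCc3c[nH]cn3)nnc2CCc2c[nH]c3ccccc23)cc1Cl`, is 1H-imidazol-4-yl in place of aminomethyl on a saturated chain carbon, two bonds along the chain from an aromatic carbon. No measured step matches this change, so nothing shown gives its size or direction. Going by the values given here, what the data show is only that every compound of this shared core, whether it carries the aminopropyl chain or, as compound 1 does, the imidazolylethyl chain, sits at the limit. The expectation for compound 4 is thus that it stays at the limit, with no step beyond the scatter in this assay that can be foreseen. The estimate for compound 4 is 15000 nM, in the range 4000 nM to 60000 nM, which as a step means a step that the limit leaves unreadable from compound 3 to compound 4.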

Compound 4, inhibition constant: > 10000 nM
Compound 4: no number, only a limit; the forecaster's own chance of this, stated with the estimate: 80%; the middle value is on the limit's open side.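

In this assay compound 4 gives > 10000 nM, a limit of the assay, so neither its step from compound 3 nor its step from compound 1 can be read in size. The compounds shown leave open whether any change on the shared core brings a value inside the limit: the limit of > 10000 nM in this assay, at which 4 of the 4 values shown sit.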